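The source may report more compounds than this note shows. Statements on the series, on what has been measured and on what is new or still open speak of the compounds shown alone.

Measured so far in an ADME assay on Raji cells (Homo sapiens) for cytotoxicity, with a stated time of 72 h (on this read-out lower numbers stand for an effect already at smaller amounts and higher numbers for an effect only at larger amounts of compound), each value a limit of the assay and not a number:

compound 1 `CC(=O)c1ccc(NC(=O)Nc2cc(C)nc3ccccc23)cc1` gives > 25000 nM as a limit
compound 2 `Cc1cc(NC(=O)Nc2ccccc2N)c2ccccc2n1` gives > 25000 nM as a limit
compound 3 `Cc1cc(NC(=O)Nc2cccc(C(N)=O)c2)c2ccccc2n1` gives > 25000 nM as a limit

Compound 3 stands at > 25000 nM and this is a limit. For the measured compounds named here, the series so far shows the limit of > 25000 nM in this assay, at which 3 of the 3 values shown sit, and no measured step links any two compounds.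

Compound 4 `Cc1cc(NC(=O)Nc2cccc(N(C)C)c2)c2ccccc2n1` differs from compound 3 by dimethylamino in place of carbamoyl on an aromatic carbon, meta to a large group dimethylamino in place of carbamoyl on an aromatic carbon with the rest of the structure unchanged.

The expectation in this assay rests on compound 3, whose > 25000 nM is only a limit. The expected change is a number no higher from compound 3 to compound 4 (the limit leaves the size open) and it is not expected to go beyond the scatter, with any movement expected toward smaller amounts. A further limit is the likeliest reading. The estimate for compound 4 is 25000 nM with an expected range from 8000 nM to 50000 nM should a number be reported.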

Compound 4, half-maximal effective concentration: > 25000 nM
Compound 4 ended at the assay's limit (the forecaster's own chance of this, stated with the estimate: 70%); the middle value lies on the limit itself.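

For the compounds shown here, compound 3 and compound 4 both sit at a limit and not at a number, so no step between them can be read in this assay. The compounds shown leave open what change to the shared core, if any, would give a number instead of the limit: the limit of > 25000 nM in this assay, at which 4 of the 4 values shown sit.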